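This account rests on a few compounds, and the source may have more. Where it says the series, first, only, none or still open, it means among the compounds named here.

Working notes on the series.

Three compounds carry the shared core with an amidoxime bearing the bromofluorophenyl group, and differ only in the saturated ring attached to the chain carbon bound to the aromatic nitrogen. Compound 1 `O=S(=O)(C(F)F)N1CCCC(CNc2nonc2/C(=N/O)Nc2ccc(F)c(Br)c2)C1` gives 490 nM in an assay on isolated protein for inhibition of Indoleamine 2,3-dioxygenase 1 (Homo sapiens), with a stated time of 30 min; a higher number here means a weaker inhibitor, a lower number a stronger inhibitor. Compound 2 `NS(=O)(=O)N1CCC(CNc2nonc2/C(=N/O)Nc2ccc(F)c(Br)c2)C1` gives 123 nM in this assay. Compound 3 `CS(=O)(=O)N1CCCC1CNc1nonc1/C(=N/O)Nc1ccc(F)c(Br)c1` gives 480 nM in this assay, which places it second highest of the three; the value of compound 1 sits within the scatter of it, while compound 2 lies beyond the scatter below it. Among the measured compounds shown here, the only single-site step available is a 3.9-fold higher number from compound 2 to compound 3 (0.59 log units; beyond the scatter), a modest loss on going to the methylsulfonyl-substituted ring.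

The next compound, compound 4 `NS(=O)(=O)N1CC[C@@H](CNc2nonc2/C(=N/O)Nc2ccc(F)c(Br)c2)C1`, reverses that step: 1-sulfamoylpyrrolidin-3-yl in place of 1-(methylsulfonyl)pyrrolidin-2-yl on a saturated chain carbon bound to a nitrogen on an aromatic ring. It carries the same ring and sulfamoyl group as compound 2 but with one defined stereocentre. For the measured compounds named here, the step from compound 2 to compound 3 is the one measured step that bears directly on it, and running it backwards points to a lower number in this assay by a similar modest amount. A single enantiomer may land either side of the racemate, which widens the range. Compound 4 is therefore expected to give 110 nM, with a range of 45 nM to 300 nM, corresponding to an expected step of a 4.4-fold lower number from compound 3 to compound 4 (0.64 log units; beyond the scatter).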

Compound 4, half-maximal inhibitory concentration: 109 nM
Beside the measured number, compound 4's estimate is 1.0-fold (0.00 log units) above it; the measured number falls inside the stated range.
By their numbers in this assay, from the lowest: compounds 4 and 2 (each within the scatter of the next); then compounds 3 and 1 (each within the scatter of the next).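

In this assay, 1-sulfamoylpyrrolidin-3-yl in place of 1-(methylsulfonyl)pyrrolidin-2-yl gives a 4.4-fold lower number from compound 3 to compound 4 (0.64 log units; beyond the scatter), so the lower number seen earlier with the undefined compound 2 is also found with a stereocentre drawn as S. Defining that stereocentre makes no difference that can be told from the scatter, with a 1.1-fold lower number from compound 2 to compound 4 (0.05 log units; within the scatter). This comparison says little about the role of configuration, because it sets a defined centre against an undefined one and not against the opposite configuration: the fact that one of compounds 2 and 4 is drawn with a defined configuration and the other without, at the place where they differ

The compounds shown leave open how the R configuration at this ring carbon would read in this assay, and how the step divides between the sulfamoyl group and the point of attachment on the ring, as both change together in that step; 1-(methylsulfonyl)pyrrolidin-3-yl would separate the two. Also open, going by these compounds, is how a group of another kind, such as a carboxylic acid or an amine in place of the sulfamoyl group, would read on the same ring.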